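This account rests on a few compounds, and the source may have more. Where it says the series, first, only, none or still open, it means among the compounds named here.

The measured compounds:
Compound 1 `Cc1ccc(NC(=O)CSc2nccn2-c2cccc3ccccc23)c(Br)c1` gives 29400 nM in an ADME assay on MT4 cells (Homo sapiens) for cytotoxicity, read by MTT assay; a higher number here means that more compound is tolerated, a lower number that less compound is tolerated.
Compound 2 `O=C(CSc1nccn1-c1ccc(Cl)cc1)Nc1ccccc1F` gives > 345000 nM in this assay, which is a limit of the assay and not a number.
Compound 3 `O=C(CSc1nccn1-c1ccc(Cl)cc1)Nc1ccccc1[N+](=O)[O-]` gives > 321000 nM in this assay, again a limit and not a number.

Compound 2 therefore stands only at a limit in this assay. Of the three values shown, two are limits, and only compound 1 carries a number.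

Compound 4 `COc1ccc(-n2ccnc2SCC(=O)Nc2ccccc2F)cc1` differs from compound 2 by methoxy in place of chloro on an aromatic carbon. Going by the values given here, the only measured step between compounds that differ in one place is a step that the two limits leave unreadable from compound 2 to compound 3; its size is unreadable because the limit of > 345000 nM in this assay, at which 1 of the 3 values shown sits, and the limit of > 321000 nM in this assay, at which 1 of the 3 values shown sits, cap both of its ends. No measured step touches the exchange of chloro for methoxy, so nothing among the shown values argues for a change of any size in this assay. The expectation for compound 4 is thus a step that stays within the scatter, an at least 1.0-fold lower number from compound 2 to compound 4 (0.00 log units; that floor lies within the scatter), with the value most likely reported again as a limit. Compound 4 is estimated at 340000 nM, with a range from 120000 nM to 600000 nM.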

Compound 4, half-maximal cytotoxic concentration: >= 41900 nM
Compound 4: only a limit was reported (the forecaster's own chance of this, stated with the estimate: 70%); the middle value does not contradict the limit.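

Compound 2 and compound 4 both stand only at limits in this assay, and no step can be read between them. The compounds shown leave open whether methoxy in place of chloro on an aromatic carbon changes the concentration tolerated in this assay at all, and by how much.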